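A few compounds are considered here, and "the series" means these few. Any claim that something is new, unique, unknown or untested is made for them only; others in the source may bear on it.

In a functional assay on M21 cells (Homo sapiens) for antiproliferative activity, read by sulforhodamine B assay, with a stated time of 48 h (on this read-out lower numbers stand for stronger inhibition and higher numbers for weaker inhibition), compound 1 `COc1ccc(OS(=O)(=O)c2ccc(N3CCN(C)C3=O)cc2)cc1OC` gives 8500 nM. Compound 2 `COc1ccc(OS(=O)(=O)c2ccc(N3CCN(C)C3=O)cc2)cc1` reaches only the limit of this assay, > 100000 nM, so no number is known for it. The change that separates the two, (methoxy in place of hydrogen on an aromatic carbon), produced an at least 11-fold lower number from compound 2 to compound 1 (1.07 log units; beyond the scatter), and the size of that step is bounded by the limit of > 100000 nM in this assay, at which 1 of the 3 values shown sits, rather than by a second number. Compound 3 `CCN1CCN(c2ccc(S(=O)(=O)Oc3cccc(OC)c3)cc2)C1=O` gives 7000 nM in this assay; set beside compound 1, this value lies within the usual scatter, so the two stand as equals here. How the core of compound 3 differs from the core of compound 2 is not broken down here.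

Compound 4 `CCN1CCN(c2ccc(S(=O)(=O)Oc3cc(OC)cc(OC)c3)cc2)C1=O` has not yet been measured in this assay. It differs from compound 3 by methoxy in place of hydrogen on an aromatic carbon. Among the measured compounds shown here, this is the same kind of change as the one from compound 2 to compound 1, but not the same: there the entering methoxy sat ortho to a methoxy group and meta to a large group, whereas in compound 4 it sits meta to a large group and meta to a methoxy group. Because compound 1 gives 8500 nM after the earlier step, an added methoxy on this ring can be expected to be tolerated; since the place differs, he expects a smaller step than the earlier one, a 1.4-fold lower number from compound 3 to compound 4 (0.15 log units; within the scatter). His estimate for compound 4 in this assay is 5000 nM, with a range from 1000 nM to 30000 nM.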

Compound 4, half-maximal inhibitory concentration: 4200 nM
Beside the measured number, compound 4's estimate is 1.2-fold (0.08 log units) above it; low and high end bracket the measured number.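

In this assay the added methoxy gives a 1.7-fold lower number from compound 3 to compound 4 (0.22 log units; within the scatter), so compound 3 and compound 4 stand as equals here, and the change does not carry over from the earlier core at the same size: the same change on two cores in this assay, an at least 11-fold lower number (1.07 log units; beyond the scatter) from compound 2 to compound 1 and a 1.7-fold lower number (0.22 log units; within the scatter) from compound 3 to compound 4, at least 7.0-fold (0.84 log units) apart, beyond the scatter of two such steps. Compound 2 stands at > 100000 nM, which is a limit of the assay and not a number, so the earlier step has a bound and no fixed size. The two steps differ both in the core and in the place where the methoxy enters, so this pair does not show whether the core, the place or both set the size of the step, and two steps alone give no rule for the series.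

The compounds shown leave open whether a methoxy entering in the place it takes in compound 4 would give a step of similar size on the core of compound 2, which would separate the core from the place. They also leave open how a hydroxyl, an amine or a longer chain such as ethoxy would compare with that methoxy on the same ring, and how a propyl chain would compare with the ethyl of compound 3 and compound 4.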